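The compounds below may be only part of what the source reports. "The series", "measured", "known", "first", "only" and "open" are said of these compounds alone.

Measured compounds:
compound 2, `CCCCCCCCCCCCC1(C(=O)Nc2c(OC)cc(OC)cc2OC)CC1`, giving 58 nM
compound 1, `CCCCCCCC/C=C/CCCCCCCC(=O)Nc1cccc(C)c1[N+](=O)[O-]`, giving 12000 nM

In an assay on microsomes from intestine for inhibition of acyl-CoA:cholesterol acyltransferase (Oryctolagus cuniculus) (on this read-out lower numbers stand for stronger inhibition and higher numbers for weaker inhibition), compound 2 stands at the lower of the two numbers, and compound 1 stands far above it, a gap well beyond the scatter. The two differ in many places at once, so nothing can be said about which part of the structure carries that gap.

Compound 3, `CCCCCCCCCCCCCCC1(C(=O)Nc2c(OC)cc(OC)cc2OC)CC1`, differs from compound 2 in one place: ethyl in place of hydrogen on a saturated chain carbon, ten or more bonds along the chain from a saturated ring carbon. Among the measured compounds shown here, no pair of measured compounds isolates a change of this kind, so the expectation rests on compound 2 alone. A lengthening of the saturated chain this far from the ring is expected to move the read-out little, if at all: the step from compound 2 to compound 3 is estimated as a 1.1-fold lower number from compound 2 to compound 3 (0.02 log units; within the scatter), not beyond the scatter. Compound 3 is therefore expected to give 55 nM, with a range from 20 nM to 160 nM.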

Compound 3, half-maximal inhibitory concentration: 49 nM
The estimate for compound 3 lay 1.1-fold (0.05 log units) above the measured number; measured number inside the range.
By their numbers in this assay, from the lowest: compounds 3 and 2 (each within the scatter of the next); then compound 1.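

In this assay, among the compounds shown here, the pair gives the first reading of a single change at this position: a 1.2-fold lower number from compound 2 to compound 3 (0.07 log units; within the scatter). The two numbers therefore cannot be told apart, and ethyl in place of hydrogen on a saturated chain carbon, ten or more bonds along the chain from a saturated ring carbon, leaves compound 3 level with compound 2 within the scatter. No measurement available here accounts for this result.

This single pair leaves open whether a longer chain would also stay within the scatter, and whether an amine or a carboxylic acid at this position would do the same. It also says nothing about which part of the structure carries the wide gap to compound 1, which differs from compound 2 in many places at once.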